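Sulfonyl aryl variation and clearance in the quinoline sulfone series

This account rests on a few compounds, and the source may have more. Where it says the series, first, only, none or still open, it means among the compounds named here.

Two members of the series carry a measurement in an ADME assay on microsomes from liver (Homo sapiens) for metabolic stability, tested at 2.5 uM; a lower number here means slower removal, a higher number faster removal of the compound. Compound 1 `O=S(=O)(c1cc(F)cc(F)c1)c1cnc2cc(F)ccc2c1-c1cccc(F)c1` gives 0.06 mL/min in this assay. Within the data shown here, compound 2 `COc1ccc(S(=O)(=O)c2cnc3cc(F)ccc3c2-c2cccc(F)c2)cc1` gives 2.94 mL/min, the higher of the two numbers; the only step recorded so far is a 49-fold higher number from compound 1 to compound 2 (1.69 log units; beyond the scatter), and compound 2 stands at the top of what has been measured.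

Compound 3 `O=S(=O)(c1cccc(F)c1)c1cnc2cc(F)ccc2c1-c1cccc(F)c1` is the next point. Relative to compound 2 the change is 3-fluorophenyl in place of 4-methoxyphenyl on a sulfonyl sulfur. Among the measured compounds shown here, the one step that bears on this is the earlier exchange of the aryl group on the sulfonyl sulfur, a 49-fold higher number from compound 1 to compound 2 (1.69 log units; beyond the scatter), which moved the number a long way. Compound 3 brings a fluorine back onto that ring and removes the methoxy group, so the exchange runs partly back toward compound 1, though not all the way to the 3,5-difluorophenyl of compound 1. A large fall in this assay is therefore expected, estimated as a 12-fold lower number from compound 2 to compound 3 (1.07 log units; beyond the scatter). For compound 3 the estimate is 0.25 mL/min, with a range from 0.07 mL/min to 0.9 mL/min, placed between compound 1 and compound 2 but nearer compound 1.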

Compound 3, intrinsic clearance in a liver preparation (reported as CLH), per the amount of preparation that the assay uses: 0.24 mL/min
Compound 3: middle estimate off by 1.0-fold (0.02 log units), on the high side; the measured number falls inside the stated range.
By their numbers in this assay, from the lowest: compound 1; then compound 3; then compound 2.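

In this assay the exchange of 4-methoxyphenyl for 3-fluorophenyl on a sulfonyl sulfur gives a 12-fold lower number from compound 2 to compound 3 (1.09 log units; beyond the scatter), which covers the larger part of the distance between the two earlier compounds. The remaining change, hydrogen in place of fluoro on an aromatic carbon, gives a 4.0-fold higher number from compound 1 to compound 3 (0.60 log units; beyond the scatter); this smaller step is also beyond the scatter, so the number still responds to a single fluoro on this ring once the methoxy group is absent. Nothing at hand gives a reason for either step.

The step from compound 2 to compound 3 removes the methoxy group and adds the fluoro in one exchange, so the share of each stays unresolved, and an unsubstituted phenyl or a 4-fluorophenyl on the sulfonyl sulfur would be needed to separate them. Also open, as far as these compounds go, is whether the low numbers of the fluorinated members hold with an amine or a carboxylic acid on this ring, and how far any of these steps carries over to changes elsewhere on the shared core.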